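Removing a benzyl group from a thiophene-linked biaryl series

The source may report more compounds than this note shows. Statements on the series, on what has been measured and on what is new or still open speak of the compounds shown alone.

Compound 1 `COc1ccc(-c2sccc2-c2cc(OC)c(OC)c(OC)c2)cc1OCc1ccccc1` was tested in a functional assay on HT-1080 cells (Homo sapiens) for antiproliferative activity, read by MTT assay, with a stated time of 72 h (a lower number here means a stronger inhibitor, a higher number a weaker inhibitor), and reached only a limit of the assay, > 100000 nM. Compound 2 `COc1ccc(-c2sccc2-c2cc(OC)c(OC)c(OC)c2)cc1O` gave 1940 nM in this assay. Within the data shown here, the single change between them, (hydrogen in place of benzyl on an oxygen on an aromatic ring), produced an at least 51-fold lower number from compound 1 to compound 2 (1.71 log units; beyond the scatter).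

Compound 3 `COc1ccc(-c2cc(C(=O)O)sc2-c2cc(OC)c(OC)c(OC)c2)cc1OCc1ccccc1` likewise reached only a limit in this assay, > 100000 nM. The difference between the core of compound 3 and the core of compound 1 is not broken down here.

Compound 4 `COc1ccc(-c2cc(C(=O)O)sc2-c2cc(OC)c(OC)c(OC)c2)cc1O` carries the same change relative to compound 3, (hydrogen in place of benzyl on an oxygen on an aromatic ring), at the same place. As far as these compounds go, the expected step of an at least 5.0-fold lower number from compound 3 to compound 4 (0.69 log units; beyond the scatter) rests on an at least 51-fold lower number from compound 1 to compound 2 (1.71 log units; beyond the scatter), with uncertainty because the limit of > 100000 nM in this assay, at which 2 of the 3 values shown sit, means the true starting value of compound 3 is unknown. Compound 4 is expected to give 20000 nM in this assay.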

Compound 4, half-maximal inhibitory concentration: 11400 nM
Compound 4: the middle estimate sits 1.8-fold (0.24 log units) above what was measured, within the range that was stated.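

Replacing benzyl with hydrogen on the aromatic oxygen again lowered the number in this assay, with an at least 8.7-fold lower number from compound 3 to compound 4 (0.94 log units; beyond the scatter), so the direction of the change held on both cores shown. Set side by side, the two steps do not show whether the size of the change carries over from one core to the other: the same change on two cores in this assay, an at least 51-fold lower number (1.71 log units; beyond the scatter) from compound 1 to compound 2 and an at least 8.7-fold lower number (0.94 log units; beyond the scatter) from compound 3 to compound 4; the limit leaves it open whether they differ. As far as these compounds go, both step sizes are only minimum figures, and the true gain on either core stays unknown because of this limit: the limit of > 100000 nM in this assay, at which 2 of the 4 values shown sit.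

The compounds shown leave open how an ethyl group or a longer chain on that oxygen would compare with benzyl and hydrogen. They also leave open whether the change behaves alike on a core carrying an amide in place of the carboxylic acid.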